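Thiazole in Place of an Aryl Ring on an Amide

This account rests on a few compounds, and the source may have more. Where it says the series, first, only, none or still open, it means among the compounds named here.

Compound 1, `N#Cc1ccc(C(=O)Nc2cccc(NC(=O)COc3ccc4c(=O)ccoc4c3)c2)cc1`: 15 nM
Compound 2, `O=C(COc1ccc2c(=O)ccoc2c1)Nc1cccc(NC(=O)c2cccc([N+](=O)[O-])c2)c1`: 41 nM
Compound 3, `Cc1cc(C(=O)Nc2cccc(NC(=O)COc3ccc4c(=O)ccoc4c3)c2)ccc1C(F)(F)F`: 43 nM

Three compounds share one core and differ only in the ring attached to the carbonyl carbon of the outer amide. In an assay on isolated protein for inhibition of Rho-associated protein kinase 2 (Homo sapiens), read by scintillation counting, radiometric assay and 33P incorporation, with a stated time of 40 min, in the presence of a further agent that is not named here (on this read-out higher numbers stand for weaker inhibition and lower numbers for stronger inhibition), compound 1 gives 15 nM, compound 2 gives 41 nM and compound 3 gives 43 nM. Compound 3 has the highest number of the three, but compound 2 sits within the scatter of it, so the two cannot be ordered; only compound 1 stands apart, as the step of a 2.9-fold higher number from compound 1 to compound 3 (0.46 log units; beyond the scatter) shows.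

Compound 4, `O=C(COc1ccc2c(=O)ccoc2c1)Nc1cccc(NC(=O)c2cnc(C(F)(F)F)s2)c1`, continues this variation: a group of 9 heavy atoms (4 carbon, 1 nitrogen, 3 fluorine, 1 sulfur; one five-membered aromatic ring with 2 hetero atoms) in place of a group of 11 heavy atoms (8 carbon, 3 fluorine; one six-membered aromatic ring of carbon only), on a carbonyl carbon. The measured steps that bear on it are all changes of the same ring on the same carbonyl carbon: a 2.7-fold higher number from compound 1 to compound 2 (0.44 log units; beyond the scatter), a 2.9-fold higher number from compound 1 to compound 3 (0.46 log units; beyond the scatter) and a 1.0-fold higher number from compound 2 to compound 3 (0.02 log units; within the scatter). All three are modest or within the scatter, which suggests this position tolerates different rings without large swings. None of them, however, exchanges a six-membered carbon ring for a five-membered ring with two hetero atoms, so the direction of the new step is uncertain. A step of a 1.1-fold lower number from compound 3 to compound 4 (0.03 log units; within the scatter) in this assay is therefore expected for compound 4, essentially no change beyond the scatter. Compound 4 is estimated at 40 nM, with a range from 14 nM to 120 nM.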

Compound 4, half-maximal inhibitory concentration: 10 nM
Compound 4: middle estimate off by 4.0-fold (0.60 log units), on the high side; the measured number lies below the stated range.
By their numbers in this assay, from the lowest: compounds 4 and 1 (each within the scatter of the next); then compounds 2 and 3 (each within the scatter of the next).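

In this assay, putting 2-(trifluoromethyl)-1,3-thiazol-5-yl on the carbonyl carbon gives a 4.3-fold lower number from compound 3 to compound 4 (0.63 log units; beyond the scatter) and a 4.1-fold lower number from compound 2 to compound 4 (0.61 log units; beyond the scatter), which shows that a five-membered aromatic ring with two hetero atoms is accepted at this position and can give stronger inhibition than some six-membered carbon rings. Against the 4-cyanophenyl ring there is a 1.5-fold lower number from compound 1 to compound 4 (0.18 log units; within the scatter), so compound 1 and compound 4 cannot be ordered, and two quite different rings reach the same level here. Trifluoromethyl is present in both compound 3 and compound 4, so that group alone does not fix the number at this position.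

Nothing in the available data explains why this ring exchange has the effect seen. The compounds shown also leave open whether the thiazole ring needs its trifluoromethyl group, since a methyl group or an amine in its place on the same ring could either keep the level of compound 4 or lose it.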